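This account rests on a few compounds, and the source may have more. Where it says the series, first, only, none or still open, it means among the compounds named here.

In an ADME assay on CCRF-CEM cells (Homo sapiens) for antiproliferative activity, with a stated time of 48 h (a lower number here means a stronger inhibitor, a higher number a weaker inhibitor), compound 1 `C=C(Br)C(=O)Nc1ccc(/C=C/C(=O)c2ccc(Cl)cc2)cc1` gives 950 nM and compound 2 `C=C(Br)C(=O)Nc1ccc(/C=C/C(=O)c2ccc(OC)cc2)cc1` gives 1400 nM. For the measured compounds named here, the only measured step, a 1.5-fold higher number from compound 1 to compound 2 (0.17 log units; within the scatter), is methoxy in place of chloro on an aromatic carbon. It lies within the scatter, so compound 2 stands level with compound 1 on these two numbers.

Compound 3 `C=C(Br)C(=O)Nc1ccc(/C=C/C(=O)c2cccs2)cc1` carries thiophen-2-yl in place of 4-methoxyphenyl on a carbonyl carbon. Going by the values given here, no measured compound contains thiophen-2-yl, so no measured step matches this change directly. Among the compounds with values here, the nearest evidence is the small step of a 1.5-fold higher number from compound 1 to compound 2 (0.17 log units; within the scatter), which exchanges only one group on an aromatic carbon, whereas the new change replaces the whole 4-methoxyphenyl. That step therefore bears on the new change only loosely, and two compounds give a thin basis for any forecast.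

No step beyond the scatter is expected in this assay, and no direction can be supported. The estimated step is a 1.2-fold lower number from compound 2 to compound 3 (0.07 log units; within the scatter). For compound 3 the estimated value is 1200 nM, with an expected range of 500 nM to 2800 nM.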

Compound 3, half-maximal inhibitory concentration: 730 nM
Compound 3: middle estimate off by 1.6-fold (0.22 log units), on the high side, within the range that was stated.
By their numbers in this assay, from the lowest: compounds 3, 1 and 2 (each within the scatter of the next).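

Exchanging the whole aromatic group on the carbonyl carbon, rather than one group on that ring, leaves the reading in this assay level: thiophen-2-yl in place of 4-methoxyphenyl gives a 1.9-fold lower number from compound 2 to compound 3 (0.28 log units; within the scatter), and thiophen-2-yl in place of 4-chlorophenyl gives a 1.3-fold lower number from compound 1 to compound 3 (0.11 log units; within the scatter). This position therefore accepts a five-membered aromatic ring with 1 hetero atom and 5 heavy atoms in place of a six-membered aromatic ring of carbon only, with 8 heavy atoms in the 4-methoxyphenyl case, and all three compounds stand within the scatter of one another. Nothing measured in this set speaks to the origin of this level reading.

Still open, on these data alone, is whether a non-aromatic group such as cyclohexyl, a longer alkyl chain, or an aromatic ring carrying an amine or a carboxylic acid would move the number beyond the scatter at this carbonyl carbon. The three compounds also share the rest of the core, so they leave open what exchanging the bromo group for hydrogen or methyl would do in this assay.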